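Dropping a Ring Methyl and Cytotoxicity Toward MRC5 Cells

This account rests on a few compounds, and the source may have more. Where it says the series, first, only, none or still open, it means among the compounds named here.

Measured so far in an ADME assay on MRC5 cells (Homo sapiens) for cytotoxicity, read by resazurin assay, with a stated time of 72 h; a higher number here means a weaker inhibitor, a lower number a stronger inhibitor:
compound 1 `O=[N+]([O-])c1cn2c(n1)OC(COc1cccc(-c3ccc(F)cc3F)n1)CC2`: > 64000 nM, a limit of this assay rather than a number.
compound 2 `CC1(COc2ncc(-c3ccc(F)cc3)cn2)CCn2cc([N+](=O)[O-])nc2O1`: 57000 nM.
compound 3 `CC1(COc2cccc(-c3ccc(F)cc3F)n2)CCn2cc([N+](=O)[O-])nc2O1`: > 64000 nM, again a limit, not a number.

Within the data shown here, compound 2 is thus the only one with a number. The change from compound 3 to compound 1, (hydrogen in place of methyl on a saturated ring carbon), gives a step that the two limits leave unreadable from compound 3 to compound 1, and its size cannot be read because both ends sit at the limit of > 64000 nM in this assay, at which 2 of the 3 values shown sit. The same change applied to compound 2, (hydrogen in place of methyl on a saturated ring carbon), gives compound 4 `O=[N+]([O-])c1cn2c(n1)OC(COc1ncc(-c3ccc(F)cc3)cn1)CC2`; the difference between the cores of compound 2 and compound 3 is not broken down here. Compound 4 is expected to stay near compound 2, a step of a 1.1-fold higher number from compound 2 to compound 4 (0.02 log units; within the scatter), because compound 2 gives 57000 nM and the earlier step shows nothing readable. Compound 4 is estimated at 60000 nM, between 30000 nM and 120000 nM.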

Compound 4, half-maximal inhibitory concentration: > 64000 nM
Compound 4 was reported as a limit; the forecaster's own chance of this, stated with the estimate: 55%; middle value at least 1.0-fold (0.02 log units) from the limit.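

Replacing methyl with hydrogen on a saturated ring carbon gives, in this assay, an at least 1.1-fold higher number from compound 2 to compound 4 (0.05 log units; that floor lies within the scatter). That figure is only a floor, because compound 4 stands at a limit of the assay rather than at a number: the limit of > 64000 nM in this assay, at which 3 of the 4 values shown sit.

The step from compound 3 to compound 1 cannot be read, so there is no second size to set beside the first, and whether the change carries over unaltered from one core to the other is not shown. On these data alone, what an ethyl group or an amine in place of the methyl would do on this ring carbon remains open, as does the size of this change on either core when both ends give a readable number.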